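The source may hold more compounds than are shown below. What is called first, only, known or untested is meant among the compounds shown, and "the series" means these compounds.

Measured compounds:
- compound 1, `CC(C)(C)C(=O)OCC1(CO)C/C(=C\CCCCCCCCCCCO)C(=O)O1`, 1.34 ug/mL
- compound 2, `CCCCCOCCCCCCC/C=C1\CC(CO)(COC(=O)C(C)(C)C)OC1=O`, 1.03 ug/mL

Both compounds were tested in a functional assay on MOLT-4F cells (Homo sapiens) for antiproliferative activity; a lower number here means a stronger inhibitor of growth, a higher number a weaker inhibitor of growth. Compound 1 gives 1.34 ug/mL, which is the highest of the two numbers, and compound 2 gives 1.03 ug/mL. Going by the values given here, the single measured step, a 1.3-fold lower number from compound 1 to compound 2 (0.11 log units; within the scatter), exchanged the end of the long chain, pentyloxy in place of 4-hydroxybutyl on a saturated chain carbon, seven bonds along the chain from a double-bonded chain carbon, and it stayed within the scatter.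

Compound 3, `CC(=O)NCCCCCCCCCCCCCCC/C=C1\CC(CO)(COC(=O)C(C)(C)C)OC1=O`, is not yet measured. It differs from compound 1 by 4-acetamidobutyl in place of hydroxy on a saturated chain carbon, ten or more bonds along the chain from a double-bonded chain carbon. This change again touches only the far end of the chain, while the shared core of compound 1 is kept.

The step from compound 1 to compound 2 is the only one that bears on this, and because a 1.3-fold lower number from compound 1 to compound 2 (0.11 log units; within the scatter) was within the scatter, an end-of-chain exchange of this kind is expected to give no step beyond the scatter in this assay. Compound 3 is therefore estimated at 1.5 ug/mL, with a range from 0.6 ug/mL to 4 ug/mL, which means an expected step of a 1.1-fold higher number from compound 1 to compound 3 (0.05 log units; within the scatter).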

Compound 3, concentration for 50% growth inhibition: 6.35 ug/mL
Compound 3: the middle estimate sits 4.2-fold (0.63 log units) below what was measured, outside the stated range (above it).
By their numbers in this assay, from the lowest: compounds 2 and 1 (each within the scatter of the next); then compound 3.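

In this assay the far end of the long chain proves able to produce a real step: 4-acetamidobutyl in place of hydroxy gives a 4.7-fold higher number from compound 1 to compound 3 (0.68 log units; beyond the scatter) and so a weaker inhibitor of growth. The comparison with the pentyloxy end points the same way, with 8-acetamidooctyl in place of pentyloxy giving a 6.2-fold higher number from compound 2 to compound 3 (0.79 log units; beyond the scatter) and so showing that compound 3 stands apart from both earlier compounds, which lie within the scatter of each other. No measurement available here accounts for this loss of growth inhibition.

Compound 3 carries an acetamido end and a longer chain at the same time, so the compounds shown leave open which of the two goes with the step. An acetamido end on a chain the length of that in compound 1 would separate the two, and a free amine or a carboxylic acid at the chain end would show whether other nitrogen or acid end groups behave in the same way.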